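Benzyl substituent changes on a shared pyrazole core

The compounds below may be only part of what the source reports. "The series", "measured", "known", "first", "only" and "open" are said of these compounds alone.

Compound 1 `CC1(C)c2[nH]nc(NC(=O)c3ccccc3)c2CN1Cc1cccc(I)c1` gives 1360 nM in an assay on Sf21 cells for inhibition of high affinity nerve growth factor receptor (Homo sapiens), read by HTRF, with a stated time of 30 min, in the presence of a further agent that is not named here; a lower number here means a stronger inhibitor, a higher number a weaker inhibitor. Compound 2 `CC1(C)c2[nH]nc(NC(=O)c3ccccc3)c2CN1Cc1cc(F)cc(F)c1` gives 190 nM in this assay.

Among the compounds with values here, compound 2 stands with the lowest number of the two measured, the only other point being compound 1, and the step of a 7.2-fold lower number from compound 1 to compound 2 (0.85 log units; beyond the scatter) is the sole measured comparison.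

Compound 3 `CC1(C)c2[nH]nc(NC(=O)c3ccccc3)c2CN1Cc1cc(F)cc(C(F)(F)F)c1` has not yet been measured. Its difference from compound 2 is trifluoromethyl in place of fluoro on an aromatic carbon. Within the data shown here, the one step that bears on this is a 7.2-fold lower number from compound 1 to compound 2 (0.85 log units; beyond the scatter), in which a benzyl ring bearing a single large halogen was exchanged for one bearing two small fluoro groups and the number fell substantially. Compound 3 moves partway back toward the larger substituent: one fluoro remains, the other is replaced by trifluoromethyl. A step in the opposite direction to that of compound 1 to compound 2 is therefore expected in this assay, but smaller, since one fluoro is kept. The estimated value for compound 3 is 420 nM, with a range from 140 nM to 1300 nM, which corresponds to an expected step of a 2.2-fold higher number from compound 2 to compound 3 (0.34 log units; beyond the scatter).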

Compound 3, half-maximal inhibitory concentration: 1000 nM
Compound 3: the middle estimate sits 2.4-fold (0.38 log units) below what was measured; the measured number falls inside the stated range.
By their numbers in this assay, from the lowest: compound 2; then compounds 3 and 1 (each within the scatter of the next).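

The change from compound 2 to compound 3 alters a single group on the benzyl ring, and in this assay it gives a 5.3-fold higher number from compound 2 to compound 3 (0.72 log units; beyond the scatter). Within the data shown here, this is the first reading at this position with the other fluoro held constant, whereas the step from compound 1 alone exchanged one pattern of ring substituents for another and could not be assigned to any one position. Here, replacing a fluoro of one heavy atom with a trifluoromethyl of four heavy atoms is enough to raise the number beyond the scatter, leaving compound 2 clearly lowest of the three, with its steps to both other compounds beyond the scatter.

With only fluoro and trifluoromethyl compared at this position, the compounds shown leave open whether a chloro, a methyl, a methoxy or a nitrile group, or plain hydrogen, would stay close to compound 2 or move with compound 3, and so whether the rise follows the number of heavy atoms at all. Nothing measured here bears on why the number rises.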